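Amide nitrogen change and a carbonyl swap in the series

This account rests on a few compounds, and the source may have more. Where it says the series, first, only, none or still open, it means among the compounds named here.

Compound 1 `N#C/C(=C\N1CCN(C(=O)c2ccco2)C1=S)C(=O)Nc1ccc(Cl)cc1` and compound 2 `N#C/C(=C\N1CCN(C(=O)c2ccco2)C1=S)C(N)=O` share the same core and differ only at the amide-type nitrogen. In a functional assay on UACC-62 cells (Homo sapiens) for inhibition, read by sulforhodamine B assay, with a stated time of 48 h (on this read-out higher numbers stand for weaker inhibition of growth and lower numbers for stronger inhibition of growth), compound 1 gives 16900 nM, and compound 2 gives 14000 nM; the two numbers sit within the scatter of one another, so compound 2 cannot be set apart from compound 1 on what has been measured. For the measured compounds named here, the single step seen so far, a 1.2-fold lower number from compound 1 to compound 2 (0.08 log units; within the scatter), shows that a hydrogen in place of 4-chlorophenyl on the amide-type nitrogen leaves the read-out essentially unchanged. Compound 3 `N#C/C(=C\N1CCN(C(=O)c2ccco2)C1=S)C(=O)c1ccccc1` is the next member: phenyl in place of amino on a carbonyl carbon. Going by the values given here, no measured step alters the carbonyl carbon itself; the only comparison that bears on it is the change at the amide-type nitrogen, a 1.2-fold lower number from compound 1 to compound 2 (0.08 log units; within the scatter), which was within the scatter. On that basis no step beyond the scatter is expected in this assay, and no change at the digits printed from compound 2 to compound 3 (within the scatter) is the estimated change. Compound 3 is therefore expected to give about 14000 nM, within 5000 nM to 40000 nM.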

Compound 3, concentration for 50% growth inhibition: 12900 nM
For compound 3 the middle estimate is 1.1-fold (0.04 log units) above the measured one; the measured number falls inside the stated range.
By their numbers in this assay, from the lowest: compounds 3, 2 and 1 (each within the scatter of the next).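

In this assay, the step of a 1.1-fold lower number from compound 2 to compound 3 (0.04 log units; within the scatter) and the step of a 1.3-fold lower number from compound 1 to compound 3 (0.12 log units; within the scatter) show that the change can reach the carbonyl carbon itself: the amide-type nitrogen of compounds 1 and 2 is gone, carbamoyl has become benzoyl, and the read-out still does not separate the compounds. For the compounds shown here, until now, only the group on that nitrogen had varied, so this is the first indication that the nitrogen and its hydrogen-bond donor can be replaced by phenyl at this position without a step beyond the scatter. No supporting data are available to explain this flat result.

Still open, on these data alone, is whether any group on this carbonyl carbon can move the number beyond the scatter, such as a hydroxyl giving a carboxylic acid, a methoxy giving a methyl ester, or a piperidine giving a tertiary amide. Also open, as far as these compounds go, is whether changing the shared core elsewhere, for example replacing the nitrile with a methyl ester, would do so.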